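The compounds below may be only part of what the source reports. "The series", "measured", "known", "first", "only" and "open" are said of these compounds alone.

The series shares one core, seen in compound 1 `CC(C)(C)C(=O)N1Cc2c(NC(=O)c3ccncc3)n[nH]c2C1(C)C`, compound 2 `CN1CCC(C(=O)N2Cc3c(NC(=O)Nc4cccc(F)c4)n[nH]c3C2(C)C)CC1` and compound 3 `CN1CCC(C(=O)Nc2n[nH]c3c2CN(C(=O)C(C)(C)C)C3(C)C)CC1`. In a physicochemical assay for solubility, at pH 7 (a lower number here means a less soluble compound, a higher number a more soluble compound), compound 1 gives 205000 nM. Compound 2 reaches only a limit of the assay in this assay, reported as > 225000 nM. Compound 3 likewise stops at a limit in this assay, reported as > 225000 nM. For the measured compounds named here, the one measured step, an at least 1.0-fold higher number from compound 1 to compound 3 (0.04 log units; that floor lies within the scatter), ends at a limit and shows nothing beyond the scatter; it also concerns a different part of the molecule. Compound 2 thus stands at the upper edge of what this assay reports, namely (the limit of > 225000 nM in this assay, at which 2 of the 3 values shown sit). Compound 4 `CN1CCC(C(=O)N2Cc3c(NC(=O)c4ccccc4)n[nH]c3C2(C)C)CC1` differs from compound 2 by phenyl in place of (3-fluorophenyl)amino on a carbonyl carbon. Going by the values given here, no measured step touches this position, so the expectation rests on compound 2 alone, whose reading of > 225000 nM is a limit. Compound 4 is therefore expected to stay among the more soluble members, with the step of an at least 1.2-fold lower number from compound 2 to compound 4 (0.09 log units; that floor lies within the scatter) estimated as small or none beyond the scatter. Compound 4 is estimated at 180000 nM, within a range from 70000 nM to 225000 nM.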

Compound 4, solubility: > 225000 nM
Compound 4: a limit, no number (the forecaster's own chance of this, stated with the estimate: 45%); middle value at least 1.2-fold (0.09 log units) away from the limit.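

No new step can be read, since compound 2 and compound 4 both stop at a limit in this assay, leaving the exchange of (3-fluorophenyl)amino for phenyl without a size. The compounds shown leave open how compound 2 and compound 4 compare beyond that edge: the limit of > 225000 nM in this assay, at which 3 of the 4 values shown sit.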